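The source may hold more compounds than are shown below. What is called first, only, known or untested is meant among the compounds shown, and "the series" means these compounds.

Two compounds share a core built from a pyrrole amide joined through a quaternary carbon to a substituted phenyl ether. In an assay on HL-60 cells for agonist activity at vitamin D3 receptor (Homo sapiens), read by microscopy, with a stated time of 96 h (on this read-out lower numbers stand for an effect already at smaller amounts and higher numbers for an effect only at larger amounts of compound), compound 1 `C#CCNC(=O)c1ccc(C(CC)(CC)c2ccc(OCC(=O)C(C)(C)C)c(C)c2)n1CC` gives 2200 nM, while compound 2 `CCn1c(C(=O)NCCCN(C)C)ccc1C(CC)(CC)c1ccc(OCC(O)C(C)(C)C)c(C)c1` gives 37 nM, the lowest of the two numbers; compound 1 stands beyond the scatter from it, but the two differ in two places, so those values alone cannot be split into separate steps.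

Compound 3 `C#CCNC(=O)c1ccc(C(CC)(CC)c2ccc(OCC(O)C(C)(C)C)c(C)c2)n1CC` keeps the alcohol of compound 2 and changes only the amide substituent: ethynyl in place of 2-(dimethylamino)ethyl on a saturated chain carbon bound to an amide-type nitrogen. Going by the values given here, no measured pair isolates this change. The amide group is shared with compound 1, which gives a far higher number, yet compound 1 also carries a ketone, so the effect of the amide substituent alone is uncertain. A loss of potency of a moderate size is expected in this assay, the step from compound 2 to compound 3 being estimated as a 5.4-fold higher number from compound 2 to compound 3 (0.73 log units; beyond the scatter). Compound 3 is therefore estimated at 200 nM, within a range from 40 nM to 1200 nM.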

Compound 3, half-maximal effective concentration: 240 nM
Estimate against measurement, compound 3: 1.2-fold (0.08 log units) below; measured number inside the range.
By their numbers in this assay, from the lowest: compound 2; then compound 3; then compound 1.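

In this assay, the step of a 6.5-fold higher number from compound 2 to compound 3 (0.81 log units; beyond the scatter) comes from replacing 2-(dimethylamino)ethyl with ethynyl on a saturated chain carbon bound to an amide-type nitrogen, so this amide substituent clearly affects the read-out when the alcohol is kept. With the propargyl amide held constant, 1-hydroxy-2,2-dimethylpropyl in place of (tert-butyl)carbonyl gives a 9.2-fold lower number from compound 1 to compound 3 (0.96 log units; beyond the scatter), so the change on the ether side matters too, and the gap that could not be divided before now falls into two steps, each beyond the scatter. Nothing available explains why either change has this effect.

As far as these compounds go, it remains open whether the alcohol and ketone would differ by a similar step with the 3-(dimethylamino)propyl amide. A primary amine, a carboxylic acid or a longer chain at the end of the amide substituent would show how far this position can be varied.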